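The source may hold more compounds than are shown below. What is called first, only, known or untested is meant among the compounds shown, and "the series" means these compounds.

Measured compounds in an ADME assay on HepG2 cells (Homo sapiens) for cytotoxicity, read by luminescence, with a stated time of 72 h; on this read-out higher numbers stand for an effect only at larger amounts of compound and lower numbers for an effect already at smaller amounts:

Compound 1, `CCOC(=O)c1c(-c2cccc(Oc3ccccc3)c2)[nH]c2cc(OC)ccc2c1=O`, gives > 21500 nM, which is a limit of the assay and not a number.
Compound 2, `CCOC(=O)c1c(-c2cccc(OC(F)(F)F)c2)[nH]c2cc(OC)ccc2c1=O`, gives > 21500 nM, likewise a limit.
Compound 3, `CCOC(=O)c1c(-c2cccc(Oc3ccccc3)c2)[nH]c2cc(F)cc(F)c2c1=O`, gives > 21500 nM, again a limit.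

The change from compound 1 to compound 2 is trifluoromethyl in place of phenyl on an oxygen on an aromatic ring. In this assay it reads as a step that the two limits leave unreadable from compound 1 to compound 2. For the measured compounds named here, both values stand at the limit of > 21500 nM in this assay, at which 3 of the 3 values shown sit, so nothing can be said about the direction or size of this step; the two values show only that neither compound reached a readable effect within the tested range. Compound 3 carries the same phenoxy group as compound 1 but on a different core; the difference between the two cores is not broken down here, and its value, being a limit, likewise gives no number to compare.

Compound 4, `CCOC(=O)c1c(-c2cccc(OC(F)(F)F)c2)[nH]c2cc(F)cc(F)c2c1=O`, is not yet measured in this assay. It differs from compound 3 by trifluoromethyl in place of phenyl on an oxygen on an aromatic ring, the same change as that from compound 1 to compound 2, at the same place. The expectation for compound 4 rests on compound 3 sitting at > 21500 nM and on (the limit of > 21500 nM in this assay, at which 3 of the 3 values shown sit), where every measured value of the series sits. The step from compound 3 to compound 4 is expected to be a step that the limit leaves unreadable from compound 3 to compound 4. Compound 4 is therefore estimated at 30000 nM, within an expected range from 12000 nM to 80000 nM, and the assay is expected most likely to report only a limit again.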

Compound 4, half-maximal effective concentration: > 21500 nM
Compound 4 ended at the assay's limit (the forecaster's own chance of this, stated with the estimate: 85%); the middle value lies beyond the limit too.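

In this assay no step can be read from compound 3 to compound 4, because both stand at a limit of the assay and not at a number: the limit of > 21500 nM in this assay, at which 4 of the 4 values shown sit.

The compounds shown leave open at what concentration any of the four would reach a half-maximal effect, and whether phenoxy to trifluoromethoxy shifts that concentration on either core.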